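A few compounds are considered here, and "the series" means these few. Any claim that something is new, unique, unknown or untested is made for them only; others in the source may bear on it.

Among the compounds with values here, in a functional assay on HOP-62 cells (Homo sapiens) for inhibition, read by sulforhodamine B assay, with a stated time of 48 h, tested at 10 uM (a higher number here means more inhibition of growth at the concentration tested, a lower number less inhibition of growth), compound 1 `CC(=O)c1ccc(NC(=O)Cn2nc(-c3ccc(Cl)cc3)nc2N)cc1` gives 15.1% and compound 2 `C/C(=N\O)c1ccc(NC(=O)Cn2nc(-c3ccc(Cl)cc3)nc2N)cc1` gives 11.7%, so the two cannot be told apart and compound 1 stands level with its only measured neighbour. Compound 3 `CC(=O)c1ccc(NC(=O)Cn2nc(C(F)(F)F)nc2N)cc1` keeps the rest of compound 1 but changes one group: trifluoromethyl in place of 4-chlorophenyl on an aromatic carbon. In plain words, a small trifluoromethyl takes the place of the larger 4-chlorophenyl on an aromatic carbon. Within the data shown here, the only measured step, a number 3.4 percentage points lower from compound 1 to compound 2 (within the scatter), alters a different place in the molecule, so it says nothing direct about this swap. Among the measured compounds shown here, no measured compound shows what happens when 4-chlorophenyl is lost. Compound 1 at 15.1% leaves limited room to fall, so only a small drop is expected. The expected step is a number 6.1 percentage points lower from compound 1 to compound 3 (within the scatter), an estimate with wide uncertainty. Compound 3 is estimated at 9%, with an expected range from 0% to 24%.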

Compound 3, percent growth inhibition at one concentration: 9.94%
Estimate against measurement, compound 3: 0.9 percentage points below; the range from low to high includes it.
By their numbers in this assay, from the lowest: compounds 3, 2 and 1 (each within the scatter of the next).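

In this assay, putting trifluoromethyl on this aromatic carbon in place of 4-chlorophenyl gives a number 5.2 percentage points lower from compound 1 to compound 3 (within the scatter). Within the data shown here, this is the first look at this position, and it shows that the six-membered aromatic ring can be removed from the core of compound 1 without a difference that can be told from the scatter, although compound 1, at 15.1%, leaves only limited room for a drop to show. Nothing measured here accounts for this result.

On these data alone, it remains open whether an amine, a carboxylic acid or a longer chain at this position would move the number beyond the scatter. As far as these compounds go, it is also open whether trifluoromethyl would give a similar reading alongside the changed group of compound 2.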